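No Cytotoxicity Signal Across Three Close Analogues

The source may hold more compounds than are shown below. What is called first, only, known or untested is meant among the compounds shown, and "the series" means these compounds.

The compounds share one core, carried in compound 1 `c1ccc(-c2ccc(Cn3cncc3CNc3ccc(-c4ccc[nH]4)c(-c4ccccc4)c3)cc2)cc1`, compound 2 `CCC(=O)c1ccc(NCc2cncn2Cc2ccc(-c3ccccc3)cc2)cc1-c1ccccc1` and compound 3 `CCCC(=O)c1ccc(NCc2cncn2Cc2ccc(-c3ccccc3)cc2)cc1-c1ccccc1`. In a toxicity assay on NIH3T3 cells (Mus musculus) for cytotoxicity, read by resazurin assay (on this read-out higher numbers stand for an effect only at larger amounts of compound and lower numbers for an effect already at smaller amounts), compound 1 gives only a limit of the assay, > 10000 nM. In this assay compound 2 likewise gives only a limit, > 10000 nM. Compound 3 also gives only a limit in this assay, > 10000 nM. All three values therefore sit on one line, (the limit of > 10000 nM in this assay, at which 3 of the 3 values shown sit), and none of the three steps between them can be read: a step that the two limits leave unreadable from compound 1 to compound 2, a step that the two limits leave unreadable from compound 1 to compound 3, and a step that the two limits leave unreadable from compound 2 to compound 3.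

Compound 4 `c1ccc(-c2ccc(Cn3cncc3CNc3ccc(-c4noc5ccccc45)c(-c4ccccc4)c3)cc2)cc1` has not yet been measured. It differs from compound 3 in one place, (a group of 9 heavy atoms (7 carbon, 1 nitrogen, 1 oxygen; one five-membered aromatic ring with 2 hetero atoms, one six-membered aromatic ring of carbon only) in place of a group of 5 heavy atoms (4 carbon, 1 oxygen; no ring), on an aromatic carbon), on the same aromatic carbon that earlier carried the propanoyl, propylcarbonyl or 1H-pyrrol-2-yl group.

The measured steps bearing on this position are the two that swapped a ring for a chain at that aromatic carbon. Their size could not be read; every value is a limit. Nothing shown suggests a step beyond the scatter for compound 4 in this assay, so the step from compound 3 to compound 4 is expected to be a step that the limit leaves unreadable from compound 3 to compound 4. Compound 4 is therefore estimated at 15000 nM, in a range from 5000 nM to 50000 nM, most likely reported once more only as a limit.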

Compound 4, half-maximal effective concentration: > 10000 nM
Compound 4 was reported as a limit; the forecaster's own chance of this, stated with the estimate: 80%; the middle value is on the limit's open side.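

Compound 4 gives only a limit in this assay, as do compound 1, compound 2 and compound 3, so none of the steps from these compounds to compound 4 can be read: the limit of > 10000 nM in this assay, at which 4 of the 4 values shown sit. The compounds shown leave open at what amount any of the four would show an effect, and whether the group on that aromatic carbon changes that amount.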